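Chloro for fluoro on the pyridine of an azetidine ether

The source may hold more compounds than are shown below. What is called first, only, known or untested is meant among the compounds shown, and "the series" means these compounds.

Of the compounds shown here, two of this set have been measured in an assay on brain for binding affinity to Neuronal acetylcholine receptor; alpha4/beta2 (Rattus norvegicus); a higher number here means a weaker inhibitor, a lower number a stronger inhibitor. Compound 1 `Clc1ncccc1OC[C@@H]1CCN1` gives 0.0084 nM, and compound 2 `Fc1cncc(OC[C@@H]2CCN2)c1` gives 0.025 nM. Among these two numbers compound 2 stands at the highest; its nearest neighbour is compound 1, whose number is lower by an amount beyond the usual scatter. For the measured compounds named here, no one-place step between measured compounds is available, so the two values can only be set side by side.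

Compound 3 `Clc1cncc(OC[C@@H]2CCN2)c1` has not yet been measured. It differs from compound 2 by chloro in place of fluoro on an aromatic carbon. Compound 1, which carries a chloro group on its own core, gives 0.0084 nM, and on that basis a modest move toward a lower number is expected for compound 3, though one that may not exceed the scatter. The step from compound 2 to compound 3 is estimated as a 1.7-fold lower number from compound 2 to compound 3 (0.22 log units; within the scatter). In this assay compound 3 is expected to give 0.015 nM, with a range from 0.004 nM to 0.06 nM.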

Compound 3, inhibition constant: 0.03 nM
Beside the measured number, compound 3's estimate is 2.0-fold (0.30 log units) below it, within the range that was stated.
By their numbers in this assay, from the lowest: compound 1; then compounds 2 and 3 (each within the scatter of the next).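

For the compounds shown here, this is the first one-place step in the set: on an aromatic carbon two atoms from the ring nitrogen, chloro in place of fluoro gives a 1.2-fold higher number from compound 2 to compound 3 (0.08 log units; within the scatter) in this assay and so stays within the scatter. At this position, one halogen can therefore stand in for the other without a difference that this read-out can resolve, so compound 2 and compound 3 cannot be told apart here. No measurement at hand bears on why the two read alike.

The compounds shown leave open whether a group other than fluoro or chloro on this carbon, such as bromo, methyl, a nitrile or an amine, would stay level with compound 2 and compound 3. They also leave open whether the same exchange would read alike on the core of compound 1.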